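Ethoxy for chloro on the aryl group of compound 1

The source may hold more compounds than are shown below. What is called first, only, known or untested is meant among the compounds shown, and "the series" means these compounds.

Measured compounds:
Compound 1, `OC[C@H]1OC(n2cnc3c(-c4ccc(Cl)cc4)ncnc32)[C@H](O)[C@@H]1O`, gives 900 nM.
Compound 2, `OC[C@H]1OC(n2cnc3c(-c4ccc(F)c(F)c4)ncnc32)[C@H](O)[C@@H]1O`, gives 1400 nM.
Compound 3, `CC(=O)OC[C@H]1O[C@@H](n2cnc3c(-c4ccccc4)ncnc32)[C@H](OC(C)=O)[C@@H]1OC(C)=O`, gives 10500 nM.

All three numbers come from a functional assay on CCRF-CEM cells (Homo sapiens) for inhibition; on this read-out higher numbers stand for weaker inhibition and lower numbers for stronger inhibition. Compound 1 sits at the low end of the three: the step of a 1.6-fold higher number from compound 1 to compound 2 (0.19 log units; within the scatter) keeps compound 2 within the scatter of it, while compound 3, whose number is also shown above, lies beyond the scatter from compound 1, and no single-place step joins those two.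

Compound 4, `CCOc1ccc(-c2ncnc3c2ncn3C2O[C@H](CO)[C@@H](O)[C@H]2O)cc1`, is not yet measured. It differs from compound 1 in one place: ethoxy in place of chloro on an aromatic carbon, on an aromatic carbon of a six-membered aromatic ring of carbon only, para to a large group. None of the measured steps exchanges a substituent for an ethoxy group, so no shown step bears directly on this change. Among the compounds with values here, the only single-place step available, from compound 1 to compound 2, stayed within the scatter, which gives no sign that small changes on this ring move this assay much. On that slim basis compound 4 is expected to stay near compound 1, with the step of a 1.7-fold higher number from compound 1 to compound 4 (0.22 log units; within the scatter) as the estimate, and a wide range to reflect the lack of a direct precedent. Compound 4 is therefore estimated at 1500 nM, between 500 nM and 5000 nM.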

Compound 4, half-maximal inhibitory concentration: 600 nM
Estimate against measurement, compound 4: 2.5-fold (0.40 log units) above; low and high end bracket the measured number.
By their numbers in this assay, from the lowest: compounds 4, 1 and 2 (each within the scatter of the next, the first and the last beyond it); then compound 3.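

In this assay, ethoxy in place of chloro gives a 1.5-fold lower number from compound 1 to compound 4 (0.18 log units; within the scatter) and so shows that this place on the aromatic ring, para to a large group, accepts a substituent of 3 heavy atoms, one of them a hydrogen-bond acceptor, with no step beyond the scatter. Within the data shown here, the comparison with the difluorinated aryl group gives a 2.3-fold lower number from compound 2 to compound 4 (0.37 log units; beyond the scatter), which is the first single-place step on this aryl group to lie beyond the scatter, though only modestly, while compound 1 remains within the scatter of both neighbours. Nothing available explains either step, so the numbers describe what this exchange does in these cells but not how it does so.

The compounds shown leave open whether ethoxy is a special case or one member of a wider series, since methoxy, a longer chain such as butoxy, an amine and a carboxylic acid do not appear at this place. Among these compounds, they also leave open how the acetyl esters of compound 3 bear on the aryl changes, as that compound is joined to the others by no single-place step.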